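The source may hold more compounds than are shown below. What is called first, only, known or untested is meant among the compounds shown, and "the series" means these compounds.

Measured so far:
compound 1 `c1cnc2c(c1)CCC[C@@H]2N(CCCN1CCNCC1)Cc1cc2ccccc2cn1` gives 59%
compound 2 `CN1CCN(CCCN(C[C@H]2Cc3ccccc3CN2C)[C@H]2CCCc3cccnc32)CC1` gives 2%

In an ADME assay on microsomes from liver (Rattus norvegicus) for metabolic stability, read by LC-MS, with a stated time of 10 min, tested at 0.5 uM (a higher number here means that more of the compound is left, a lower number that less of the compound is left), compound 1 gives 59% and holds the higher of the two numbers, while compound 2 at 2% lies lower by a gap beyond the scatter. Within the data shown here, no two measured compounds differ in one place only, so the data hold no direct measure of any single change.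

The next compound to be read is compound 3 `c1cnc2c(c1)CCC[C@@H]2N(CCCN1CCNCC1)Cc1nc2ccccc2s1`, which carries 1,3-benzothiazol-2-yl in place of isoquinolin-3-yl on a saturated chain carbon bound to an amine nitrogen. Both groups hold a six-membered aromatic ring of carbon only, and the rest of the structure of compound 1 stays as it is. The expectation therefore starts from compound 1 at 59% in this assay and allows for a wide margin, given how little has been measured. The expected shift is small and downward, if there is one at all, and not beyond the scatter (a number 7 percentage points lower from compound 1 to compound 3 (within the scatter)). Compound 3 is estimated at 52% (expected range 28% to 74%).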

Compound 3, percent of the compound remaining: 21%
Beside the measured number, compound 3's estimate is 31 percentage points above it; the measured number lies below the stated range.
By their numbers in this assay, from the lowest: compound 2; then compound 3; then compound 1.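

Among these compounds, on a saturated chain carbon bound to an amine nitrogen, the choice of fused aromatic group clearly matters in this assay: 1,3-benzothiazol-2-yl in place of isoquinolin-3-yl gives a number 38 percentage points lower from compound 1 to compound 3 (beyond the scatter) and is the only direct reading of a single change. The change keeps a six-membered aromatic ring of carbon only and replaces a six-membered aromatic ring with 1 hetero atom by a five-membered aromatic ring with 2 hetero atoms, so this one place alone can move the read-out by a large margin while the rest of compound 1 stays as it is. No measurement at hand bears on the reason for this step.

Among the compounds shown here, the single step does not separate the contribution of the sulfur from that of the smaller ring, nor does it show whether the same change would have a similar size on another core. A 1,3-benzoxazol-2-yl, with oxygen in place of the sulfur, or a plain phenyl at this place would help to separate those possibilities.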